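A Methoxy Swap on an Inactive Piperazine Series

The source may report more compounds than this note shows. Statements on the series, on what has been measured and on what is new or still open speak of the compounds shown alone.

In a functional assay on BGC-823 cells (Homo sapiens) for antiproliferative activity, read by MTT assay, with a stated time of 48 h (a lower number here means a stronger inhibitor, a higher number a weaker inhibitor), compound 1 `S=c1oc(-c2ccc3c(c2)OCCO3)nn1CN1CCN(C(c2ccccc2)c2ccccc2)CC1` gives > 50000 nM, which is a limit of the assay and not a number. Compound 2 `S=c1oc(-c2ccc3c(c2)OCCO3)nn1CN1CCN(c2ccc(Cl)cc2)CC1` gives > 50000 nM, which is likewise a limit. Among the measured compounds shown here, no measured number therefore fixes where compound 2 stands, and it shares its limit with the only other compound tested.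

Compound 3 `COc1ccccc1N1CCN(Cn2nc(-c3ccc4c(c3)OCCO4)oc2=S)CC1` keeps the shared core and carries 2-methoxyphenyl in place of 4-chlorophenyl on an amine nitrogen in a ring. The expectation for it rests on (the limit of > 50000 nM in this assay, at which 2 of the 2 values shown sit). At most a small step towards stronger inhibition is expected in this assay, and that expected step is estimated as an at least 1.6-fold lower number from compound 2 to compound 3 (0.22 log units; that floor lies within the scatter). A further limit reading would be no surprise. For compound 3 the expected value is estimated at 30000 nM, with an estimated range from 8000 nM to 60000 nM.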

Compound 3, half-maximal inhibitory concentration: 19500 nM
Compound 3: middle estimate off by 1.5-fold (0.19 log units), on the high side; low and high end bracket the measured number.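

Among the compounds shown here, compound 3 is the first compound here to give a measured number rather than a limit in this assay, which shows that the group on the amine nitrogen in the ring can alter the read-out. The change from 4-chlorophenyl to 2-methoxyphenyl goes with an at least 2.5-fold lower number from compound 2 to compound 3 (0.40 log units; beyond the scatter), a step beyond the scatter that is a floor and not an exact size. Its true size stays unfixed because compound 2 gives only a limit: the limit of > 50000 nM in this assay, at which 2 of the 3 values shown sit.

On these data alone, what plain phenyl, or a phenyl bearing a carboxylic acid, would give on the same nitrogen stays open. The swap removes the chlorine and brings in the methoxy group at once, so the compounds shown cannot assign the step to either part of the change.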